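This account rests on a few compounds, and the source may have more. Where it says the series, first, only, none or still open, it means among the compounds named here.

Of the compounds shown here, two have been measured in an ADME assay on the whole organism (strain Sprague-Dawley) for pharmacokinetics, with Rattus norvegicus as the target, read by LC-MS, at a dose of 5 mg/kg by the intravenous route; a lower number here means less compound in the circulation, a higher number more compound in the circulation at the dose given. Compound 1 `C=CC(=O)N1CC[C@H](N2C(=O)N(Cc3ccccc3)Cc3cnc(Nc4ccc(N5CCN(C)CC5)cc4OC)nc32)C1` gives 1350 nM. Compound 2 `C=CC(=O)N1CC[C@H](N2C(=O)N(c3ccccc3)Cc3cnc(Nc4ccc(N5CCN(C)CC5)cc4)nc32)C1` gives 2830 nM, the higher of the two numbers, and its gap to compound 1 lies beyond the usual scatter. Compound 3 `C=CC(=O)N1CC[C@H](N2C(=O)N(c3ccccc3)Cc3cnc(Nc4ccc(N5CCN(C)CC5)cc4OC)nc32)C1` is built from compound 2 by one change, (methoxy in place of hydrogen on an aromatic carbon), so that the only difference is a methoxy in place of hydrogen on an aromatic carbon. Among the measured compounds shown here, no measured pair shows this change alone, so the step is expected to be small, at most a modest drop within the scatter, a 1.3-fold lower number from compound 2 to compound 3 (0.11 log units; within the scatter). Compound 3 is therefore estimated at 2200 nM, with a likely range from 1000 nM to 4500 nM.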

Compound 3, maximal plasma concentration: 3150 nM
Estimate against measurement, compound 3: 1.4-fold (0.16 log units) below, within the range that was stated.
By their numbers in this assay, from the lowest: compound 1; then compounds 2 and 3 (each within the scatter of the next).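

In this assay, methoxy in place of hydrogen, ortho to a large group and meta to a 4-methylpiperazin-1-yl group, gives a 1.1-fold higher number from compound 2 to compound 3 (0.05 log units; within the scatter), so this first clean reading of the change shows no effect beyond the scatter. Phenyl in place of benzyl on the amide-type nitrogen gives a 2.3-fold higher number from compound 1 to compound 3 (0.37 log units; beyond the scatter), the only single change here that exceeds the scatter. Nothing measured explains either step.

As far as these compounds go, whether a hydroxyl or an amine at the methoxy position would read the same remains open. So does the effect of a longer chain, such as phenethyl, on that nitrogen.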